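Swapping the Pyridyl Arm for a Piperazine Amide

The source may report more compounds than this note shows. Statements on the series, on what has been measured and on what is new or still open speak of the compounds shown alone.

Measured so far:
compound 1 `COc1ccc(Cl)cc1S(=O)(=O)Nc1cncc(-c2cccnc2)c1` gives 73 nM
compound 2 `COc1ccc(C(N)=O)cc1S(=O)(=O)Nc1cccnc1` gives 1490 nM

In an assay on isolated protein for inhibition of alkaline phosphatase, tissue-nonspecific isozyme (Homo sapiens) (on this read-out higher numbers stand for weaker inhibition and lower numbers for stronger inhibition), compound 1 holds the lowest number of the two, and compound 2 sits well apart from it, beyond the scatter. Compound 3 `COc1ccc(Cl)cc1S(=O)(=O)Nc1cncc(C(=O)N2CCN(C)CC2)c1` has not been measured. It differs from compound 1 in one place: (4-methylpiperazin-1-yl)carbonyl in place of pyridin-3-yl on an aromatic carbon. Among the compounds with values here, no measured pair shows this change, so the step is unknown. On this basis compound 3 is expected to lose some potency, with a step of a 4.8-fold higher number from compound 1 to compound 3 (0.68 log units; beyond the scatter) rising beyond the scatter. The estimated value for compound 3 is 350 nM, in a range from 80 nM to 1500 nM.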

Compound 3, half-maximal inhibitory concentration: 671 nM
Compound 3: the middle estimate sits 1.9-fold (0.28 log units) below what was measured; measured number inside the range.
By their numbers in this assay, from the lowest: compound 1; then compound 3; then compound 2.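

In this assay, putting (4-methylpiperazin-1-yl)carbonyl in place of pyridin-3-yl gives a 9.2-fold higher number from compound 1 to compound 3 (0.96 log units; beyond the scatter) and shows that this aromatic carbon, two atoms from the ring nitrogen, is sensitive to the group it carries. Measurable inhibition remains with a non-aromatic ring attached through a carbonyl. No available evidence accounts for the size of this step.

Going by these compounds, whether the loss follows from removing the pyridine ring, adding the carbonyl or introducing the piperazine remains open. A phenyl ring, a morpholine amide or a dimethylamide at this carbon could help separate these changes.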